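The source may report more compounds than this note shows. Statements on the series, on what has been measured and on what is new or still open speak of the compounds shown alone.

In a functional assay with Mus musculus as the target (on this read-out lower numbers stand for an effect already at smaller amounts and higher numbers for an effect only at larger amounts of compound), compound 1 (`C=CCn1c(=O)n(CCCC)c2nc(N)nc(O)c21`) gives 11 uM, and compound 2 (`C=CCn1c(=O)n(C2C=CC(CO)O2)c2nc(N)nc(O)c21`) gives 30 uM, the higher of the two numbers. Compound 3 (`C=CCn1c(=O)n(CCCCO)c2nc(N)nc(O)c21`) is not yet measured and differs from compound 2 as follows: a group of 5 heavy atoms (4 carbon, 1 oxygen; no ring) in place of a group of 7 heavy atoms (5 carbon, 2 oxygen; one five-membered non-aromatic ring with 1 hetero atom), on an aromatic nitrogen. Among the compounds with values here, only one measured step bears on this change: a 2.7-fold higher number from compound 1 to compound 2 (0.44 log units; beyond the scatter), modest and at the same aromatic nitrogen. Compound 3 returns to a group with no ring, as in compound 1, so a partial reversal of that step is expected in this assay, toward a lower number. The expected step is a 1.7-fold lower number from compound 2 to compound 3 (0.22 log units; within the scatter), of similar or smaller size. For compound 3 the estimate is 18 uM, with an expected range of 8 uM to 40 uM.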

Compound 3, concentration for half-maximal effect: 52 uM
For compound 3 the middle estimate is 2.9-fold (0.46 log units) below the measured one; the whole stated range lies below it.
By their numbers in this assay, from the lowest: compound 1; then compounds 2 and 3 (each within the scatter of the next).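

In this assay, the 4-hydroxybutyl group with no ring does not bring the number back towards compound 1: a 1.7-fold higher number from compound 2 to compound 3 (0.24 log units; within the scatter), so the ring alone does not account for the gap between compound 1 and compound 2. Within the data shown here, the single change of hydroxy in place of hydrogen on the chain, four bonds along from the aromatic nitrogen, is itself a step beyond the scatter: a 4.7-fold higher number from compound 1 to compound 3 (0.67 log units; beyond the scatter). No supporting data explain this shift. From the compounds shown here alone, whether it belongs to the hydroxy specifically remains open; an amine or a carboxylic acid at the chain end, or a longer unsubstituted chain, would separate these readings.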